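The source may hold more compounds than are shown below. What is called first, only, known or untested is meant among the compounds shown, and "the series" means these compounds.

The measured compounds in an assay on cells for agonist activity at vitamin D3 receptor (Homo sapiens), read by microscopy; a higher number here means that more compound is needed for the effect, a lower number that less compound is needed:

Compound 1, `CCN(CC)CCCNC(=O)c1ccc(C(CC)(CC)c2ccc(C#CC(O)(CC)CC)c(C)c2)n1CC`, gives 68.9 nM in this assay.
Compound 2, `CCn1c(C(=O)On2nnc3ccccc32)ccc1C(CC)(CC)c1ccc(C#CC(O)(CC)CC)c(C)c1`, gives only a limit in this assay, > 50 nM.
Compound 3, `CCn1c(C(=O)N[C@H](C(=O)O)C(C)C)ccc1C(CC)(CC)c1ccc(C#CC(O)(CC)CC)c(C)c1`, gives 17.7 nM in this assay.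

Compound 3 has the lowest of the two numbers; the nearest is compound 1, and the step of a 3.9-fold lower number from compound 1 to compound 3 (0.59 log units; beyond the scatter) is beyond the scatter. Compound 2 sits at a limit, (the limit of > 50 nM in this assay, at which 1 of the 3 values shown sits), so the step of an at least 2.8-fold lower number from compound 2 to compound 3 (0.45 log units; beyond the scatter) is readable only as a bound.

Compound 4, `CCn1c(C(=O)NCCC(=O)O)ccc1C(CC)(CC)c1ccc(C#CC(O)(CC)CC)c(C)c1`, differs from compound 3 in one place: 2-carboxyethyl in place of 1-carboxy-2-methylpropyl on an amide-type nitrogen. Going by the values given here, no measured pair changes the carboxy-bearing side chain in this way; the one step that alters the substituent on the amide-type nitrogen, from compound 1 to compound 3, replaced a basic chain with the carboxy group and was modest. Since both compound 3 and compound 4 keep a carboxy group, a smaller change is expected, in either direction, and likely within the scatter.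

Compound 4 is expected to give 28 nM in this assay, with a range of 10 nM to 80 nM. This corresponds to an expected step of a 1.6-fold higher number from compound 3 to compound 4 (0.20 log units; within the scatter).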

Compound 4, half-maximal effective concentration: 293 nM
Compound 4: the middle estimate sits 10-fold (1.02 log units) below what was measured, outside the stated range (above it).
By their numbers in this assay, from the lowest: compound 3; then compound 1; then compound 4.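

In this assay, the group on the amide-type nitrogen proves to matter even when a carboxy group is kept: a 17-fold higher number from compound 3 to compound 4 (1.22 log units; beyond the scatter), with 2-carboxyethyl in place of 1-carboxy-2-methylpropyl. A carboxy group alone therefore does not bring the lower number, for while the earlier change gave a 3.9-fold lower number from compound 1 to compound 3 (0.59 log units; beyond the scatter), the new one gives a 4.3-fold higher number from compound 1 to compound 4 (0.63 log units; beyond the scatter), so the two carboxy-bearing chains fall on opposite sides of compound 1. The step from compound 2 to compound 4 cannot be read, as compound 2 gives only a limit: the limit of > 50 nM in this assay, at which 1 of the 4 values shown sits.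

The compounds shown do not separate the loss of the defined stereocentre from the change in chain and the loss of the branch, as compound 3 and compound 4 differ in all of these. From the compounds shown here alone, how a 1-carboxyethyl or carboxymethyl group, or the opposite stereoisomer of 1-carboxy-2-methylpropyl, would read on this nitrogen remains open.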